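A few compounds are considered here, and "the series" means these few. Any claim that something is new, unique, unknown or untested is made for them only; others in the source may bear on it.

Measured so far:
compound 1, `COc1cc(OC)c(OC)cc1/C=C/COC(=O)/C=C/c1ccc(OC)c(OC)c1`: 100%
compound 2, `COc1cc(OC)c(OC)cc1/C=C/COC(=O)/C=C/c1ccccc1Cl`: 100%

Both values come from a functional assay on the whole organism (strain Kunming) with Mus musculus as the target, with a stated time of 0.5 h, at a dose of 100 mg/kg by the intraperitoneal route; on this read-out higher numbers stand for a weaker effect at the one dose given and lower numbers for a stronger effect. Compound 2 stands level with compound 1 at the digits given; the step of no change at the digits printed from compound 1 to compound 2 (within the scatter) lies within the scatter. Compound 3, `COc1ccc(/C=C/C(=O)OC/C=C/c2cc(OC)c(OC)cc2OC)cc1`, is not yet measured. Its change from compound 2: 4-methoxyphenyl in place of 2-chlorophenyl on a double-bonded chain carbon bound to a double-bonded chain carbon. Within the data shown here, the one step that bears on it, no change at the digits printed from compound 1 to compound 2 (within the scatter), also swapped the aryl group at the same place and left this read-out unchanged, so no step beyond the scatter is expected here, no change at the digits printed from compound 2 to compound 3 (within the scatter). Compound 3 is therefore estimated at 100%, in the range 80% to 100%.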

Compound 3, a percentage reported as activity, at one dose (the size of the read-out at that dose, not a potency): 100%
Beside the measured number, compound 3's estimate shows no gap at the digits printed, and the stated range covers the measured number.
By their numbers in this assay, from the lowest: compounds 1, 2 and 3 (each within the scatter of the next).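

In this assay the swap of 2-chlorophenyl for 4-methoxyphenyl gives no change at the digits printed from compound 2 to compound 3 (within the scatter) and the loss of one methoxy from the 3,4-dimethoxyphenyl group gives no change at the digits printed from compound 1 to compound 3 (within the scatter) as well. A third aryl group at this place thus leaves the read-out level, and neither the chlorine nor the number of methoxy groups separates these compounds at this one dose. No evidence bears on this result.

Open, on these data alone, is whether an amine or a carboxylic acid on this aromatic ring would shift the read-out from that of compound 3 at 100% in this assay and whether any change to the shared core would do so.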